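Aryl groups on the core: expected step to compound 3

The source may report more compounds than this note shows. Statements on the series, on what has been measured and on what is new or still open speak of the compounds shown alone.

- compound 1 `CCOC(=O)CC1C(C(=O)OCC)=C(N)Oc2ccccc21` gives 91400 nM in a functional assay on Jurkat cells (Homo sapiens) for cytotoxicity, with a stated time of 48 h; on this read-out higher numbers stand for weaker inhibition and lower numbers for stronger inhibition
- compound 2 `CCOC(=O)CC1C(C(=O)OCC)=C(N)Oc2cccc(-c3ccccc3)c21` gives 44300 nM in this assay

Compound 1 stands highest of the two measured compounds at 91400 nM on this read-out. Compound 3 `CCOC(=O)CC1C(C(=O)OCC)=C(N)Oc2ccc(-c3cccc4ccccc34)cc21` departs from it by naphthalen-1-yl in place of hydrogen on an aromatic carbon in plain words naphthalen-1-yl in place of hydrogen on an aromatic carbon. Within the data shown here, only one measured step bears on this change, and it is modest: a 2.1-fold lower number from compound 1 to compound 2 (0.31 log units; beyond the scatter) with phenyl in place of hydrogen on an aromatic carbon. The series holds no measurement of naphthalen-1-yl, so this single step is thin support. A similarly modest move toward stronger inhibition in this assay is expected, with a wide margin. The expected change is a 2.4-fold lower number from compound 1 to compound 3 (0.38 log units; beyond the scatter) in this estimate. For compound 3 the estimated value is 38000 nM and the expected range runs from 13000 nM to 95000 nM as a working figure.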

Compound 3, half-maximal inhibitory concentration: 5830 nM
Compound 3: middle estimate off by 6.5-fold (0.81 log units), on the high side; measured number below the stated range.
By their numbers in this assay, from the lowest: compound 3; then compound 2; then compound 1.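

In this assay the aromatic carbon of the shared core proves able to carry a far larger effect than the earlier pair suggested: naphthalen-1-yl gives a 16-fold lower number from compound 1 to compound 3 (1.20 log units; beyond the scatter) as a large step, whereas phenyl gives a 2.1-fold lower number from compound 1 to compound 2 (0.31 log units; beyond the scatter) as a modest one. Compound 3 carries its group on a different aromatic carbon from compound 2, so the larger step belongs to group and position together, and neither can be credited alone. Nothing at hand accounts for the size of this step.

Open, from the compounds shown here alone, is whether phenyl on the carbon used in compound 3, or naphthalen-1-yl on the carbon used in compound 2, would give a step of this size. Also open, going by these compounds, is whether a pyridine ring or a methoxy group on that carbon would keep any of the gain.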